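Three Inactive Analogues and a Carboxyethyl Extension

The source may hold more compounds than are shown below. What is called first, only, known or untested is meant among the compounds shown, and "the series" means these compounds.

The study measured three compounds in an ADME assay on MCF-10A cells (Homo sapiens) for antiproliferative activity, read by sulforhodamine B assay, with a stated time of 48 h (on this read-out lower numbers stand for stronger inhibition and higher numbers for weaker inhibition), and found no numbered values, only limits. Compound 1 `C[C@@]12CCCC[C@H]1CC=C(O)C2=O` returned only the limit > 2000000 nM in this assay. Compound 2 `CC1(C)[C@@H]2CC3=NCC(=O)O[C@@]3(C)[C@H]1C2` likewise gave only the limit > 900000 nM. Compound 3 `CC(C)(C)OC(=O)n1cnc(C[C@H]2N=C3C[C@H]4C[C@H](C4(C)C)[C@@]3(C)OC2=O)c1` also stopped at the limit > 1300000 nM in this assay; all three therefore sit at limits, with compound 2 among them.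

Compound 4 `CC1(C)[C@@H]2CC3=N[C@@H](CCC(=O)O)C(=O)O[C@@]3(C)[C@H]1C2` is the untested relative of compound 2 (2-carboxyethyl in place of hydrogen on a saturated ring carbon). Among the compounds with values here, with no measured step between any pair to guide the size of the change, nothing beyond the scatter is expected from compound 2 to compound 4, giving an expected step that the limit leaves unreadable from compound 2 to compound 4. In this assay compound 4 is estimated at 1000000 nM, with a range from 300000 nM to 3000000 nM.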

Compound 4, half-maximal inhibitory concentration: > 1200000 nM
Compound 4 was reported as a limit; the forecaster's own chance of this, stated with the estimate: 85%; at least 1.2-fold (0.07 log units) between middle value and limit.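

Compound 2 and compound 4 both stand only as limits, so no step can be read between them. The compounds shown leave open what 2-carboxyethyl in place of hydrogen on a saturated ring carbon does in this assay.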